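Replacing pyrimidin-5-yl with 4-(trifluoromethyl)benzyl in a growth inhibition series

A few compounds are considered here, and "the series" means these few. Any claim that something is new, unique, unknown or untested is made for them only; others in the source may bear on it.

Measured in a functional assay on SGC-7901 cells (Homo sapiens) for inhibition, read by MTT assay, with a stated time of 72 h; on this read-out lower numbers stand for stronger inhibition of growth and higher numbers for weaker inhibition of growth:
Compound 1 `O=C1COc2ccc(-n3cc(C[C@H](O)COCCOC[C@@H](O)Cc4ccc(-c5ccccc5)cc4)nn3)cc2N1`: 15200 nM
Compound 2 `O[C@H](COCCOC[C@@H](O)Cc1cn(-c2cccs2)nn1)Cc1ccc(-c2ccccc2)cc1`: 33400 nM
Compound 3 `O[C@H](COCCOC[C@@H](O)Cc1cn(-c2cncnc2)nn1)Cc1ccc(-c2ccccc2)cc1`: > 100000 nM (a limit of the assay, not a number)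

Compound 3 stands last of the three, with only its limit of > 100000 nM in this assay to show. Compound 4 `O[C@H](COCCOC[C@@H](O)Cc1cn(Cc2ccc(C(F)(F)F)cc2)nn1)Cc1ccc(-c2ccccc2)cc1` carries 4-(trifluoromethyl)benzyl in place of pyrimidin-5-yl on an aromatic nitrogen of the shared core. Three measured steps changed this same group. The step of a 2.2-fold higher number from compound 1 to compound 2 (0.34 log units; beyond the scatter) was modest, while an at least 6.5-fold higher number from compound 1 to compound 3 (0.81 log units; beyond the scatter) and an at least 2.9-fold higher number from compound 2 to compound 3 (0.47 log units; beyond the scatter) were larger, and all three lie beyond the scatter. Since the last two steps both end at pyrimidin-5-yl, removing that group is expected to bring a measurable number back. The expected change is an at least 4.0-fold lower number from compound 3 to compound 4 (0.60 log units; beyond the scatter) toward stronger inhibition of growth. The estimate for compound 4 is 25000 nM with an expected range from 8000 nM to 80000 nM in this assay.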

Compound 4, concentration for 50% growth inhibition: 8700 nM
The estimate for compound 4 lay 2.9-fold (0.46 log units) above the measured number; measured number inside the range.
By their numbers in this assay, from the lowest: compounds 4 and 1 (each within the scatter of the next); then compound 2. At a limit, above all of these: compound 3.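

At this aromatic nitrogen, 4-(trifluoromethyl)benzyl brings a measurable number back, with an at least 11-fold lower number from compound 3 to compound 4 (1.06 log units; beyond the scatter). It also improves on thiophen-2-yl, with a 3.8-fold lower number from compound 2 to compound 4 (0.58 log units; beyond the scatter), while the remaining step, a 1.7-fold lower number from compound 1 to compound 4 (0.24 log units; within the scatter), sets no order between the two groups it compares. Compound 3 gives only a limit of the assay, not a number, so its step has a bound and no exact size: the limit of > 100000 nM in this assay, at which 1 of the 4 values shown sits.

Still open, going by these compounds, is whether the result follows the trifluoromethyl or the benzyl link. A plain benzyl or a 4-(trifluoromethyl)phenyl at this nitrogen would separate the two.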